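The source may report more compounds than this note shows. Statements on the series, on what has been measured and on what is new or still open speak of the compounds shown alone.

Three compounds share one core and differ only in the aryl group carried on a saturated chain carbon bound to an oxygen on an aromatic ring. In an assay on CHO cells for displacement of a labelled ligand from Alpha-1B adrenergic receptor (Homo sapiens) (on this read-out higher numbers stand for weaker inhibition and lower numbers for stronger inhibition), compound 1 `COc1cccc(OC)c1OCCNCCOc1ccccc1OCc1cccc(Cl)c1` gives 0.159 nM, compound 2 `COc1cccc(OC)c1OCCNCCOc1ccccc1OCc1ccc(Cl)cc1` gives 1 nM, and compound 3 `COc1cccc(OC)c1OCCNCCOc1ccccc1OCc1ccccc1[N+](=O)[O-]` gives 2.51 nM, the highest of the three numbers. The steps read a 6.3-fold higher number from compound 1 to compound 2 (0.80 log units; beyond the scatter), a 16-fold higher number from compound 1 to compound 3 (1.20 log units; beyond the scatter) and a 2.5-fold higher number from compound 2 to compound 3 (0.40 log units; beyond the scatter). Compound 4 `COc1ccc(COc2ccccc2OCCNCCOc2c(OC)cccc2OC)cc1` differs from compound 3 by 4-methoxyphenyl in place of 2-nitrophenyl on a saturated chain carbon bound to an oxygen on an aromatic ring. Both steps ending at the 2-nitrophenyl raised the number, and compound 4 returns to a ring substituted as the 4-chlorophenyl of compound 2 is, so a lower number is expected, near that of compound 2. For compound 4 the expected step is a 2.1-fold lower number from compound 3 to compound 4 (0.32 log units; beyond the scatter). Compound 4 is estimated at 1.2 nM, between 0.35 nM and 4 nM.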

Compound 4, inhibition constant: 0.398 nM
The estimate for compound 4 lay 3.0-fold (0.48 log units) above the measured number; measured number inside the range.
By their numbers in this assay, from the lowest: compound 1; then compound 4; then compound 2; then compound 3.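

In this assay, the aryl group at this saturated chain carbon accepts a methoxy at least as well as a chloro, with a 2.5-fold lower number from compound 2 to compound 4 (0.40 log units; beyond the scatter) as methoxy replaces chloro on an aromatic carbon, and the change from 2-nitrophenyl to 4-methoxyphenyl gives a 6.3-fold lower number from compound 3 to compound 4 (0.80 log units; beyond the scatter). Even so, 4-methoxyphenyl does not match 3-chlorophenyl, with a 2.5-fold higher number from compound 1 to compound 4 (0.40 log units; beyond the scatter). As far as these compounds go, how an aryl group carrying an amine or a carboxylic acid would read remains open, as does whether the lead of 3-chlorophenyl would hold against such groups. Nothing available accounts for these differences.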